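The compounds below may be only part of what the source reports. "The series", "measured", "known", "first", "only" and "open" are said of these compounds alone.

The measured compounds are these. Compound 1 `CCCCC[Se]c1nc(NCc2ccc(SC)cc2)c2ccccc2n1` gives > 100000 nM in a functional assay on HT-29 cells (Homo sapiens) for cytotoxicity, read by MTT assay, with a stated time of 72 h (a higher number here means that more compound is tolerated, a lower number that less compound is tolerated), which is a limit of the assay and not a number. Compound 2 `CSc1ccc(CNc2nc([SeH])nc3ccccc23)cc1` gives > 100000 nM in this assay, again only a limit. Compound 3 `Nc1nc([SeH])nc2ccccc12` gives > 100000 nM in this assay, also a limit.

Compounds 2 and 1 differ in one place, (pentyl in place of hydrogen on a selenium), and the step between them is a step that the two limits leave unreadable from compound 2 to compound 1; both values are limits, so its size cannot be read. Every value in this set sits at the limit of > 100000 nM in this assay, at which 3 of the 3 values shown sit, and nothing in the series rises above that limit. How the core of compound 3 differs from the core of compound 2 is not broken down here.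

Compound 4 `CCCCC[Se]c1nc(N)c2ccccc2n1` has not been measured. It differs from compound 3 by pentyl in place of hydrogen on a selenium, the same change that leads from compound 2 to compound 1, at a selenium with the same surroundings. From compound 3 to compound 4 the step expected in this assay is a step that the limit leaves unreadable from compound 3 to compound 4. This expectation rests on compound 3, whose value is only a limit, and on the earlier step that the two limits leave unreadable from compound 2 to compound 1, which the two limits leave unreadable. For compound 4 the estimate is 150000 nM, with a likely range from 60000 nM to 400000 nM, and most probably the assay will again report only a limit.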

Compound 4, concentration lethal to 50% of the cells: > 100000 nM
Compound 4 gave a limit, no number; the forecaster's own chance of this, stated with the estimate: 80%; the middle value does not contradict the limit.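

In this assay compound 4 gives > 100000 nM, which is a limit and not a number. Compound 3 also has only a limit, so the step between compound 3 and compound 4, pentyl in place of hydrogen on a selenium, cannot be read. The compounds shown leave open what any of them would actually measure, since every value stands at the same point: the limit of > 100000 nM in this assay, at which 4 of the 4 values shown sit.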